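A Benzyl in Place of a Methylphenyl on a Fused Core

The source may report more compounds than this note shows. Statements on the series, on what has been measured and on what is new or still open speak of the compounds shown alone.

Of the compounds shown here, two with a shared core have been tested in a functional assay on Cortical neurone cells (Mus musculus, strain C57BL/6), read by FLIPR and calcium flux, with a stated time of 8 min; on this read-out higher numbers stand for weaker inhibition and lower numbers for stronger inhibition. Compound 1 `O=c1cc(Cc2ccc(Cl)cc2)[nH]c2nc(Cc3ccc(F)cc3)nn12` gives 3650 nM in this assay. Compound 2 `Cc1ccc(-c2nc3[nH]c(-c4ccccc4)cc(=O)n3n2)cc1` gives 3210 nM in this assay; this is the lower of the two numbers, but compound 1 lies within the scatter of it, so the two cannot be told apart.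

The unmeasured compound 3 `O=c1cc(-c2ccccc2)[nH]c2nc(Cc3ccccc3)nn12` differs from compound 2 in one place: benzyl in place of 4-methylphenyl on an aromatic carbon. Compound 1 also carries a benzyl on that aromatic carbon, and with its value of 3650 nM compound 1 sits within the scatter of compound 2. No step beyond the scatter is therefore expected. The step of a 1.1-fold higher number from compound 2 to compound 3 (0.04 log units; within the scatter) is expected to be small. Compound 3 is estimated at 3500 nM in this assay, with a range from 1500 nM to 8000 nM.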

Compound 3, half-maximal inhibitory concentration: 1310 nM
Compound 3: the middle estimate sits 2.7-fold (0.43 log units) above what was measured; measured number below the stated range.
By their numbers in this assay, from the lowest: compound 3; then compounds 2 and 1 (each within the scatter of the next).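

In this assay the change from 4-methylphenyl to benzyl on this aromatic carbon, between two ring nitrogen atoms, gives a 2.5-fold lower number from compound 2 to compound 3 (0.39 log units; beyond the scatter) and so shows that this position responds to the choice of group, if only modestly. The group that leaves and the group that enters have the same heavy atom count and each holds one six-membered aromatic ring of carbon only, so the step comes from the same atoms joined differently, not from added atoms. No measurement here accounts for why this rearrangement goes with a lower number.

Still open, from the compounds shown here alone, is how this aromatic carbon would respond to a longer chain such as phenylethyl, or to an amine or a carboxylic acid. Also open, going by these compounds, is how a methoxy group on the benzyl ring would change the number.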